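The compounds below may be only part of what the source reports. "The series", "measured", "known", "first", "only" and "open" are said of these compounds alone.

Three compounds have been measured in an ADME assay on HeLa cells (Homo sapiens) for cytotoxicity, read by MTT assay, with a stated time of 24 h; a higher number here means a weaker inhibitor, a lower number a stronger inhibitor:

Compound 1, `CCN(C)C(=S)SC(=S)N(C)C`, gives 2070000 nM.
Compound 2, `CCCCN1CCN(C(=S)SC(=S)N(C)C)CC1`, gives 4100000 nM.
Compound 3, `CN(C)C(=S)SC(=S)N1CCN(c2cccc(Cl)c2Cl)CC1`, gives 1590000 nM.

Compound 2 stands at the highest of the three numbers in this assay. Its nearest neighbour is compound 1, whose number lies lower but within the scatter of repeated measurements, so no order between these two can be claimed. Compound 3 lies furthest off, with a number lower than that of compound 2 by more than the scatter allows.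

Compound 4, `CCCCSC(=S)N1CCN(C(=S)SC(=S)N(C)C)CC1`, has not been measured. It differs from compound 2 by a group of 7 heavy atoms (5 carbon, 2 sulfur; no ring) in place of a group of 4 heavy atoms (4 carbon; no ring), on an amine nitrogen in a ring. For the measured compounds named here, no measured pair in this set shows a step of this kind, so the size of the change in this assay can only be guessed. Going by the values given here, the one comparison available, compound 2 against compound 3, pairs a butyl on the ring nitrogen with a larger group and a lower number, which hints at a modest drop rather than a rise.

The step of a 1.6-fold lower number from compound 2 to compound 4 (0.21 log units; within the scatter) is therefore expected to be small and downward, probably not beyond the scatter. Compound 4 is estimated to give 2500000 nM in this assay, with a likely range from 1000000 nM to 6000000 nM.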

Compound 4, half-maximal inhibitory concentration: > 5000000 nM
Compound 4: no number, only a limit; the forecaster's own chance of this, stated with the estimate: 10%; middle value at least 2.0-fold (0.30 log units) away from the limit.
By their numbers in this assay, from the lowest: compounds 3, 1 and 2 (each within the scatter of the next, the first and the last beyond it). At a limit, above all of these: compound 4.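

In this assay, the group of 7 heavy atoms in place of butyl, on the amine nitrogen in the ring, gives an at least 1.2-fold higher number from compound 2 to compound 4 (0.08 log units; that floor lies within the scatter). The value of compound 4 is a limit and not a number, so the full size of this step cannot be read: the limit of > 5000000 nM in this assay, at which 1 of the 4 values shown sits. For the compounds shown here, the earlier compounds offered no step in one place, and this first one shows only that the larger open-chain group, with its 2 hydrogen-bond acceptors, brings no fall in the number at this position.

The compounds shown leave open which part of the entering group matters, since only this one replacement can be read. They also leave open how an octyl chain or a carboxylic acid on the same ring nitrogen would compare.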